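This account rests on a few compounds, and the source may have more. Where it says the series, first, only, none or still open, it means among the compounds named here.

Compound 1 `COc1cc(-c2ccnc3cc(-c4c[nH]c5ccccc45)nn23)cc(OC)c1OC`: 40 nM
Compound 2 `COc1cc(-c2ccnc3cc(-c4ccc(C)cc4)nn23)cc(OC)c1OC`: 21 nM
Compound 3 `COc1cc(-c2ccnc3cc(-c4ccc5cc[nH]c5c4)nn23)cc(OC)c1OC`: 55 nM

In a functional assay on B16-F0 cells (Mus musculus) for inhibition, read by CCK-8 assay, with a stated time of 48 h (a lower number here means a stronger inhibitor, a higher number a weaker inhibitor), compound 1 lies within the scatter of both other compounds, with a 1.9-fold lower number from compound 1 to compound 2 (0.28 log units; within the scatter) and a 1.4-fold higher number from compound 1 to compound 3 (0.14 log units; within the scatter). Among the compounds with values here, the only step beyond the scatter is a 2.6-fold higher number from compound 2 to compound 3 (0.42 log units; beyond the scatter), which is modest.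

Compound 4 `COc1cc(-c2ccnc3cc(-c4cn(C(=O)OC(C)(C)C)c5ccccc45)nn23)cc(OC)c1OC` keeps the core of compound 1 and carries tert-butoxycarbonyl in place of hydrogen on an aromatic nitrogen of the five-membered ring: tert-butoxycarbonyl in place of hydrogen on an aromatic nitrogen. Within the data shown here, no measured compound has a substituent on that nitrogen, so the three steps bear on the change only indirectly. They replace the whole group on the aromatic carbon, and even a 2.6-fold higher number from compound 2 to compound 3 (0.42 log units; beyond the scatter) stays modest. A modest step towards a higher number is therefore expected, with low confidence in its direction. The expected change is a 2.3-fold higher number from compound 1 to compound 4 (0.35 log units; beyond the scatter). For compound 4 the estimated value is 90 nM, with an expected range of 25 nM to 350 nM.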

Compound 4, half-maximal inhibitory concentration: 3070 nM
For compound 4 the middle estimate is 34-fold (1.53 log units) below the measured one; measured number outside the range, above it.
By their numbers in this assay, from the lowest: compounds 2, 1 and 3 (each within the scatter of the next, the first and the last beyond it); then compound 4.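

In this assay, within the data shown here, tert-butoxycarbonyl on the aromatic nitrogen of the five-membered ring gives a 77-fold higher number from compound 1 to compound 4 (1.89 log units; beyond the scatter), far larger than any step among the earlier compounds, where replacing the whole group on the aromatic carbon gave at most a 2.6-fold higher number from compound 2 to compound 3 (0.42 log units; beyond the scatter). This nitrogen is therefore a sensitive position for this substituent, although the earlier series gave no sign of this, and the hydrogen there is not needed in every compound, as 4-methylphenyl, which has no such nitrogen, gives a 1.9-fold lower number from compound 1 to compound 2 (0.28 log units; within the scatter). Nothing measured on these compounds accounts for the large step.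

On these data alone, it remains open whether the step follows the carbonyl or the tert-butyl part of the entering group. Methyl or acetyl on the same nitrogen would separate the two.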